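Linker ester exchange: working notes on compounds 2 and 3

The source may hold more compounds than are shown below. What is called first, only, known or untested is meant among the compounds shown, and "the series" means these compounds.

Measured so far:
compound 1 `CC(C)OC(=O)c1sc(N(COP(=O)(OC(C)(C)C)OC(C)(C)C)c2ncccn2)nc1-c1ccccn1`: 380 nM
compound 2 `CC(C)OC(=O)c1sc(N(COP(=O)(OC(C)(C)C)OC(C)(C)C)c2ncccn2)nc1-c1cnccn1`: 980 nM

In a functional assay on Huh-7 cells (Homo sapiens) for cytotoxicity, read by MTT assay, with a stated time of 72 h (on this read-out lower numbers stand for higher toxicity in this test and higher numbers for lower toxicity in this test), compound 1 gives 380 nM and compound 2 gives 980 nM. Among the compounds with values here, the one measured step, a 2.6-fold higher number from compound 1 to compound 2 (0.41 log units; beyond the scatter), alters only the aromatic group on the shared core and leaves the substituted nitrogen and its side chain untouched. Compound 2 therefore stands as the highest of the two numbers in this assay.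

Compound 3 `CC(C)OC(=O)OCN(c1ncccn1)c1nc(-c2cnccn2)c(C(=O)OC(C)C)s1` differs from compound 2 by a group of 6 heavy atoms (4 carbon, 2 oxygen; no ring) in place of a group of 12 heavy atoms (8 carbon, 3 oxygen, 1 phosphorus; no ring), on an oxygen on a saturated carbon. Within the data shown here, no measured step changes this part of the molecule, so nothing measured bears on the change, and no direction can be read from the two numbers. The step of a 1.1-fold lower number from compound 2 to compound 3 (0.04 log units; within the scatter) is expected to stay within the scatter, but with a broad range around that expectation. For compound 3 the estimate in this assay is 900 nM, with a range from 250 nM to 3500 nM.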

Compound 3, half-maximal cytotoxic concentration: 95 nM
For compound 3 the middle estimate is 9.5-fold (0.98 log units) above the measured one, outside the stated range (below it).
By their numbers in this assay, from the lowest: compound 3; then compound 1; then compound 2.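

In this assay, the group on an oxygen on a saturated carbon proves to be a strong handle on the number: isopropoxycarbonyl in place of the group of 12 heavy atoms gives a 10-fold lower number from compound 2 to compound 3 (1.01 log units; beyond the scatter). Within the data shown here, the earlier step changed only the aromatic group on the shared core, so this is the first reading at this position, and it points towards higher toxicity in this test with the aromatic group held constant. Nothing available accounts for the size or direction of this step.

On these data alone, whether the same exchange gives a step of similar size with pyridin-2-yl on the shared core remains open, since the position has been read on a single pair. As far as these compounds go, how other groups on this oxygen, such as ethoxycarbonyl or pivaloyl, would read is also open.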